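The source may hold more compounds than are shown below. What is called first, only, known or untested is meant among the compounds shown, and "the series" means these compounds.

Measured compounds:
- compound 1, `O=C(CN1CN(c2ccccc2)C2(CCN(C(=O)c3ccc(C4CCCCC4)cc3)CC2)C1=O)N1CCC(CO)CC1`, 1100 nM
- compound 2, `O=C(CN1CN(c2ccccc2)C2(CCN(C(=O)c3ccc(C4CCCCC4)cc3)CC2)C1=O)NCO`, 8300 nM
- compound 3, `CS(=O)(=O)NCCNC(=O)CN1CN(c2ccccc2)C2(CCN(C(=O)c3ccc(C4CCCCC4)cc3)CC2)C1=O`, 2100 nM

Compound 3 stands second highest of the three numbers in an assay on HEK293 cells for displacement of a labelled ligand from NPC1-like intracellular cholesterol transporter 1 (Homo sapiens); a lower number here means a stronger inhibitor, a higher number a weaker inhibitor: one of its measured steps is a 1.9-fold higher number from compound 1 to compound 3 (0.28 log units; within the scatter), while the other is a 4.0-fold lower number from compound 2 to compound 3 (0.60 log units; beyond the scatter). The step to compound 4, `CCOC(=O)C1CCCN(C(=O)CN2CN(c3ccccc3)C3(CCN(C(=O)c4ccc(C5CCCCC5)cc4)CC3)C2=O)C1`, is 3-(ethoxycarbonyl)piperidin-1-yl in place of (2-(methanesulfonamido)ethyl)amino on a carbonyl carbon. Within the data shown here, two measured steps bear on it. The step of a 1.9-fold higher number from compound 1 to compound 3 (0.28 log units; within the scatter) shows that opening the piperidine ring of compound 1 into a chain amide changed little. The step of a 7.5-fold higher number from compound 1 to compound 2 (0.88 log units; beyond the scatter) shows that a small open-chain amide is weaker than the ring amide of compound 1. Compound 4 returns to a six-membered ring amide, now carrying an ethoxycarbonyl group rather than hydroxymethyl. Nothing measured separates these two substituents, so the expectation for compound 4 rests on compound 1. The expected step is a 1.6-fold lower number from compound 3 to compound 4 (0.21 log units; within the scatter), a slightly lower number than compound 3. Compound 4 is therefore estimated at 1300 nM, within 500 nM to 3500 nM.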

Compound 4, half-maximal inhibitory concentration: 4200 nM
Compound 4: middle estimate off by 3.2-fold (0.51 log units), on the low side; measured number outside the range, above it.
By their numbers in this assay, from the lowest: compounds 1, 3, 4 and 2 (each within the scatter of the next, the first and the last beyond it).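

In this assay, returning to a six-membered ring amide did not by itself keep the number of compound 1: the change to 3-(ethoxycarbonyl)piperidin-1-yl on this carbonyl carbon gives a 3.8-fold higher number from compound 1 to compound 4 (0.58 log units; beyond the scatter). Compound 4 cannot be told apart from either open-chain amide, with a 2.0-fold higher number from compound 3 to compound 4 (0.30 log units; within the scatter) and a 2.0-fold lower number from compound 2 to compound 4 (0.30 log units; within the scatter), so among these four compounds a ring on this carbonyl carbon does not by itself give the lower number. Nothing measured here accounts for these differences.

From the compounds shown here alone, in the step from compound 1, the kind of substituent and its place on the piperidine ring change together, and it remains open which of them matters. A 4-(ethoxycarbonyl)piperidin-1-yl group would separate the two, and a carboxylic acid in place of the ethyl ester would test the ester itself.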